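A few compounds are considered here, and "the series" means these few. Any claim that something is new, unique, unknown or untested is made for them only; others in the source may bear on it.

Compounds measured in a functional assay on BT-549 cells (Homo sapiens) for cytotoxicity, read by sulforhodamine B assay, with a stated time of 48 h, tested at 1 uM; on this read-out lower numbers stand for a stronger effect and higher numbers for a weaker effect at the one concentration tested:
- compound 1, `COc1cc(-c2cc(/C=C/C(=O)c3ccc(N)cc3)[nH]n2)cc(OC)c1OC`: 73%
- compound 2, `COc1cc(-c2cc(/C=C/C(=O)c3ccc(Cl)c(Cl)c3)[nH]n2)cc(OC)c1OC`: 92%
- compound 3, `COc1ccc(C(=O)/C=C/c2cc(-c3cc(OC)c(OC)c(OC)c3)n[nH]2)cc1`: 93%

Compound 3 gives the highest of the three numbers in this assay. Its nearest neighbour is compound 2, whose number lies within the scatter of it, as the step of a number 1 percentage points higher from compound 2 to compound 3 (within the scatter) shows. Compound 1 lies furthest away, and the step of a number 20 percentage points higher from compound 1 to compound 3 (beyond the scatter) is beyond the scatter. Compound 4, `COc1cc(-c2cc(/C=C/C(=O)c3ccc(F)c(F)c3)[nH]n2)cc(OC)c1OC`, has not yet been measured in this assay. It differs from compound 3 in one place: 3,4-difluorophenyl in place of 4-methoxyphenyl on a carbonyl carbon.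

Going by the values given here, the step that bears most on this change is the one from compound 2 to compound 3, where a number 1 percentage points higher from compound 2 to compound 3 (within the scatter); there a dihalogenated phenyl on the same carbonyl carbon was exchanged for the 4-methoxyphenyl and the read-out did not move beyond the scatter. The step of a number 19 percentage points higher from compound 1 to compound 2 (beyond the scatter) shows that this part of the molecule can matter, but that involved an amino group that compound 3 and compound 4 do not carry. Because a number 1 percentage points higher from compound 2 to compound 3 (within the scatter) was within the scatter, compound 4 is expected to sit close to compound 3, with a step of about a number 2 percentage points lower from compound 3 to compound 4 (within the scatter). The estimate for compound 4 in this assay is therefore 91%, with a range from 80% to 100%.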

Compound 4, a percentage reported as activity, at one concentration (the size of the read-out at that concentration, not a potency): 92%
For compound 4 the middle estimate is 1 percentage points below the measured one; the measured number falls inside the stated range.
By their numbers in this assay, from the lowest: compound 1; then compounds 2, 4 and 3 (each within the scatter of the next).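

In this assay, the 3,4-difluorophenyl on the carbonyl carbon reads the same as the 4-methoxyphenyl (a number 1 percentage points lower from compound 3 to compound 4 (within the scatter)) and the 3,4-dichlorophenyl (no change at the digits printed from compound 2 to compound 4 (within the scatter)). Going by these compounds alone, this adds a direct exchange of fluorine for chlorine at both ring places, which the earlier compounds did not offer, and that exchange leaves the read-out within the scatter. Within the data shown here, the 4-aminophenyl of compound 1 remains the only group here that stands apart, now also from the 3,4-difluorophenyl (a number 19 percentage points higher from compound 1 to compound 4 (beyond the scatter)).

No measurement shown here accounts for these numbers. On these data alone, it remains open whether a carboxylic acid, a dimethylamino group or a longer chain on this phenyl would read like the 4-aminophenyl or like the other three groups.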